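From a Hexyl Chain to a Propylsulfonyl Group

The compounds below may be only part of what the source reports. "The series", "measured", "known", "first", "only" and "open" are said of these compounds alone.

Of the compounds shown here, two have so far been measured in a functional assay (aorta) with Oryctolagus cuniculus as the target; on this read-out lower numbers stand for stronger inhibition and higher numbers for weaker inhibition. Compound 1 `NS(=O)(=O)c1ccc(-c2nn(Cc3ccccc3F)c3ncccc23)o1` gives 8000 nM. Within the data shown here, compound 2 `CCCCCCc1cnc(-c2nn(Cc3ccccc3F)c3ncccc23)nc1N` gives 1040000 nM, the higher of the two numbers and thus the weaker inhibitor; its gap to compound 1 lies beyond the scatter, and since no single-change step joins the two, only the two numbers themselves can be compared. Compound 3 `CCCS(=O)(=O)c1cnc(-c2nn(Cc3ccccc3F)c3ncccc23)nc1N` is the next to be measured. propylsulfonyl in place of hexyl on an aromatic carbon The entering group contains sulfur and two oxygens, as does the group on compound 1, whose 8000 nM sits well below the number of compound 2, so some gain seems plausible, though compound 1 also differs in other places. Compound 3 is therefore expected to inhibit more strongly than compound 2, an estimated step of a 17-fold lower number from compound 2 to compound 3 (1.24 log units; beyond the scatter). The value for compound 3 is estimated at 60000 nM, within a range from 5000 nM to 600000 nM.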

Compound 3, half-maximal inhibitory concentration: 378000 nM
The estimate for compound 3 lay 6.3-fold (0.80 log units) below the measured number; the measured number falls inside the stated range.
By their numbers in this assay, from the lowest: compound 1; then compound 3; then compound 2.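

In this assay, putting propylsulfonyl in place of hexyl gives a 2.8-fold lower number from compound 2 to compound 3 (0.44 log units; beyond the scatter) and this step, though modest, lies beyond the usual scatter, so the number does respond to the group on this aromatic carbon, ortho to an amino group. The two groups hold the same count of 6 heavy atoms, yet the entering one has 3 carbons, a sulfur and 2 oxygens, with 2 hydrogen-bond acceptors where hexyl has 0. Nothing measured here explains why the number moved.

Still open, from the compounds shown here alone, is whether the shift belongs to the sulfonyl part or simply to the shorter carbon chain, which a plain propyl chain on this carbon would help separate. Going by these compounds, how an amine or a carboxylic acid at this place would read also remains unknown.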